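Hydroxyacetamide for urea in a fluorinated tetralin sulfone series

The source may report more compounds than this note shows. Statements on the series, on what has been measured and on what is new or still open speak of the compounds shown alone.

Measured so far:
compound 1 `O=C(CO)NC[C@@H]1CCCc2cc(S(=O)(=O)c3cccc(F)c3)ccc21`, 0.1 nM
compound 2 `O=S(=O)(c1cccc(F)c1)c1cc(F)c2c(c1)CCC[C@H]2CNCCO`, 0.159 nM
compound 3 `NC(=O)NC[C@@H]1CCCc2cc(S(=O)(=O)c3cccc(F)c3)cc(F)c21`, 0.2 nM

In an assay on isolated protein for displacement of a labelled ligand from 5-hydroxytryptamine receptor 6 (Homo sapiens) (a higher number here means a weaker inhibitor, a lower number a stronger inhibitor), compound 3 gives the highest of the three numbers, yet it sits within the scatter of compound 2 and of compound 1. For the measured compounds named here, the one single-point step, a 1.3-fold higher number from compound 2 to compound 3 (0.10 log units; within the scatter), exchanged the amine substituent without effect beyond the scatter. Compound 4 `O=C(CO)NC[C@@H]1CCCc2cc(S(=O)(=O)c3cccc(F)c3)cc(F)c21` follows from compound 3 by hydroxymethyl in place of amino on a carbonyl carbon. Compound 1 carries the same (hydroxymethyl)carbonyl group on a core lacking the ring fluorine and gives 0.1 nM, close to compound 3. Going by the values given here, no measured step addresses this exact exchange, so no movement beyond the scatter is expected. Compound 4 is therefore estimated at 0.13 nM, range 0.05 nM to 0.4 nM, a step of a 1.5-fold lower number from compound 3 to compound 4 (0.19 log units; within the scatter).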

Compound 4, inhibition constant: 0.251 nM
For compound 4 the middle estimate is 1.9-fold (0.29 log units) below the measured one; the measured number falls inside the stated range.
By their numbers in this assay, from the lowest: compounds 1, 2, 3 and 4 (each within the scatter of the next, the first and the last beyond it).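

In this assay, hydroxymethyl in place of amino on a carbonyl carbon stays within the scatter (a 1.3-fold higher number from compound 3 to compound 4 (0.10 log units; within the scatter)), as does the exchange of the substituent on the amine nitrogen (a 1.6-fold higher number from compound 2 to compound 4 (0.20 log units; within the scatter)). Fluoro in place of hydrogen on an aromatic carbon is the only one of these steps beyond the scatter, and it is modest (a 2.5-fold higher number from compound 1 to compound 4 (0.40 log units; beyond the scatter)). Nothing available explains that step. Still open, on these data alone, is whether a carboxylic acid or a longer chain on the carbonyl carbon would also stay within the scatter of compound 4.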